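A Chloro Group on the Anilide of Compound 2

This account rests on a few compounds, and the source may have more. Where it says the series, first, only, none or still open, it means among the compounds named here.

Compound 1, `COc1cc2c(cc1OC)C(CC(=O)O)CC2`, gives 27.5% in a functional assay on the whole organism (strain Wistar) for inhibition, with Rattus norvegicus as the target, read by paw edema, with a stated time of 3 h, at a dose of 100 mg/kg; on this read-out higher numbers stand for more inhibition at the one dose given (going by the name of the read-out) and lower numbers for less inhibition.
Compound 2, `COc1cc2c(cc1OC)C(CC(=O)Nc1ccccc1)CC2`, gives 36.2% in this assay.

Compound 2 has the higher of the two numbers, yet a number 8.7 percentage points higher from compound 1 to compound 2 (within the scatter) lies within the scatter, so the two are not separated. Compound 3, `COc1cc2c(cc1OC)C(CC(=O)Nc1cccc(Cl)c1)CC2`, differs from compound 2 by chloro in place of hydrogen on an aromatic carbon. Among the compounds with values here, the one measured step touches the carbonyl end, not the aromatic ring, so it gives no guide to this change. The expected step, a number 0.8 percentage points higher from compound 2 to compound 3 (within the scatter), stays within the scatter. Compound 3 is therefore estimated at 37%, with a range from 20% to 54%.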

Compound 3, a percentage reported as inhibition, in the whole organism at one dose (the size of the read-out at that dose, not a potency): 24.6%
Estimate against measurement, compound 3: 12.4 percentage points above; low and high end bracket the measured number.
By their numbers in this assay, from the lowest: compounds 3, 1 and 2 (each within the scatter of the next, the first and the last beyond it).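

Chloro in place of hydrogen on the aromatic ring gives a number 11.6 percentage points lower from compound 2 to compound 3 (beyond the scatter) in this assay, the first measured step at this place and the only step here that lies beyond the scatter. Hydroxy replaced by (3-chlorophenyl)amino on the carbonyl carbon gives a number 2.9 percentage points lower from compound 1 to compound 3 (within the scatter) and so does not separate the two compounds. Nothing available here explains the effect of the chloro group.

From the compounds shown here alone, whether this loss is specific to chloro remains open. A fluoro, methyl or methoxy group on the same aromatic carbon could help to answer that.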